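The compounds below may be only part of what the source reports. "The series", "measured", "known", "first", "only" and "open" are said of these compounds alone.

Measured so far in an ADME assay on microsomes from liver (Homo sapiens) for metabolic stability, read by LC-MS, using NADPH, with stated times of 5 min and 30 min, tested at 1 uM; on this read-out higher numbers stand for fast clearance and lower numbers for slow clearance:
- compound 1 `CN(C)C(=O)c1cc(-c2cnc(NCc3c(F)ccc4c3CCO4)c3cn[nH]c(=O)c23)n(C)n1` gives 21 mL.min-1.g-1
- compound 3 `O=C(Nc1ccccc1)c1cnc(NCc2c(F)ccc3c2CCO3)n2cnnc12` gives 14 mL.min-1.g-1
- compound 2 `O=C1CCCN1c1cnc(NCc2c(F)ccc3c2CCO3)n2cnnc12` gives < 3 mL.min-1.g-1, which is a limit of this assay and not a number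

Compound 1 holds the highest of the two numbers shown, but compound 3 sits within the usual scatter of it, so no order between these two can be read. Compound 2 sits at the limit (the limit of < 3 mL.min-1.g-1 in this assay, at which 1 of the 3 values shown sits). Going by the values given here, the one step that can be sized, an at least 4.6-fold higher number from compound 2 to compound 3 (0.66 log units; beyond the scatter), is at least modest and runs on the core shared by compounds 2 and 3, which is not the core of compound 1.

Compound 4 `CNC(=O)c1ccc(-c2cnc(NCc3c(F)ccc4c3CCO4)c3cn[nH]c(=O)c23)c(C)n1` differs from compound 1 in one place: 2-methyl-6-(methylcarbamoyl)pyridin-3-yl in place of 3-(dimethylcarbamoyl)-1-methyl-1H-pyrazol-5-yl on an aromatic carbon. Among the compounds with values here, no measured step covers this change. The step from compound 2 to compound 3 concerns another amide-type group on another core, and the two numbers from compounds 1 and 3 lie close together, so neither gives a direction for compound 4. The expectation is therefore a number near that of compound 1, with no step beyond the scatter: a 1.2-fold lower number from compound 1 to compound 4 (0.07 log units; within the scatter). Compound 4 is estimated at 18 mL.min-1.g-1 in this assay, expected between 8 mL.min-1.g-1 and 40 mL.min-1.g-1.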

Compound 4, intrinsic clearance in microsomes: 23 mL.min-1.g-1
Compound 4: the middle estimate sits 1.3-fold (0.11 log units) below what was measured; the measured number falls inside the stated range.
By their numbers in this assay, from the lowest: compounds 3, 1 and 4 (each within the scatter of the next). At a limit, below all of these: compound 2.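

In this assay, the first step shown on the core of compound 1 falls at the position on an aromatic carbon of a six-membered aromatic ring with 1 nitrogen, and it gives a 1.1-fold higher number from compound 1 to compound 4 (0.04 log units; within the scatter). The exchange of 3-(dimethylcarbamoyl)-1-methyl-1H-pyrazol-5-yl for 2-methyl-6-(methylcarbamoyl)pyridin-3-yl replaces a five-membered aromatic ring with a six-membered one and alters the counts of hydrogen-bond donors and acceptors, yet no difference can be read on this read-out, so at this position these two carbamoyl-bearing groups cannot be told apart. Nothing shown bears on why the two groups cannot be told apart.

On these data alone, both groups carry a carbamoyl on an aromatic ring, so it remains open whether a plain phenyl, or a ring bearing a carboxylic acid or an amine in place of the carbamoyl, would give a number beyond the scatter of these two compounds. Also open, as far as these compounds go, is whether the same holds for an unsubstituted primary amide, or for a saturated ring at this position.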